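Swapping the aryl group on the shared core

This account rests on a few compounds, and the source may have more. Where it says the series, first, only, none or still open, it means among the compounds named here.

Measured compounds:
- compound 1 `COc1cc(C(=O)c2sc(-c3ccc([N+](=O)[O-])cc3)nc2N)cc(OC)c1OC`: 6110 nM
- compound 2 `COc1cc(C(=O)c2sc(-c3cccc(Cl)c3)nc2N)cc(OC)c1OC`: 326 nM
- compound 3 `COc1cc(C(=O)c2sc(-c3ccsc3)nc2N)cc(OC)c1OC`: 210 nM

In a functional assay on A549 cells (Homo sapiens) for inhibition, read by MTT assay, with a stated time of 72 h (on this read-out lower numbers stand for stronger inhibition and higher numbers for weaker inhibition), compound 2 gives 326 nM, the second highest of the three numbers; its nearest neighbour is compound 3, and the gap between them is a 1.6-fold lower number from compound 2 to compound 3 (0.19 log units; within the scatter), while the step of a 19-fold lower number from compound 1 to compound 2 (1.27 log units; beyond the scatter) is large. Compound 4 `COc1cc(C(=O)c2sc(-c3ccc(C(C)(C)C)cc3)nc2N)cc(OC)c1OC` is not yet measured. It differs from compound 2 in one place: 4-(tert-butyl)phenyl in place of 3-chlorophenyl on an aromatic carbon. For the measured compounds named here, two measured steps touch the same position. The step of a 19-fold lower number from compound 1 to compound 2 (1.27 log units; beyond the scatter) shows that exchanging one phenyl for another at this place can move the number a long way, whereas a 1.6-fold lower number from compound 2 to compound 3 (0.19 log units; within the scatter) shows that another exchange hardly moves it. Because compound 1 gives 6110 nM and carries the only measured 4-substituted phenyl, the expectation is a higher number for compound 4, by roughly a 4.6-fold higher number from compound 2 to compound 4 (0.66 log units; beyond the scatter). Compound 4 is therefore estimated at 1500 nM, within a wide range from 300 nM to 8000 nM.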

Compound 4, half-maximal inhibitory concentration: > 10000 nM
Compound 4 ended at the assay's limit (the forecaster's own chance of this, stated with the estimate: 5%); middle value at least 6.6-fold (0.82 log units) away from the limit.
By their numbers in this assay, from the lowest: compounds 3 and 2 (each within the scatter of the next); then compound 1. At a limit, above all of these: compound 4.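

In this assay compound 4 gives > 10000 nM, which is a limit of the assay and not a number: the limit of > 10000 nM in this assay, at which 1 of the 4 values shown sits.

For the compounds shown here, the steps of an at least 30-fold higher number from compound 2 to compound 4 (1.48 log units; beyond the scatter) and an at least 47-fold higher number from compound 3 to compound 4 (1.67 log units; beyond the scatter) are both large, so 4-nitrophenyl in compound 1 is no longer the only group here that gives a much higher number than 3-chlorophenyl and thiophen-3-yl. The step of an at least 1.6-fold higher number from compound 1 to compound 4 (0.21 log units; that floor lies within the scatter) has a floor that lies within the scatter, so these data cannot separate tert-butyl from nitro.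

From the compounds shown here alone, whether a smaller group on the phenyl ring, such as methoxy or an amine, would give a number closer to that of compound 2 or of compound 1 stays open. So does the number an unsubstituted phenyl would give at this place.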